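Chloro for fluoro on an inactive lactam series

The source may report more compounds than this note shows. Statements on the series, on what has been measured and on what is new or still open speak of the compounds shown alone.

In a functional assay on PC-3 cells (Homo sapiens) for antiproliferative activity, read by MTT assay, with a stated time of 72 h (on this read-out lower numbers stand for stronger inhibition and higher numbers for weaker inhibition), compound 3 `O=C(CNc1ccc(F)cc1)N[C@H]1CCOC1=O` gives only a limit, > 64000 nM. Compound 1 `Cc1cc(Cl)ccc1NCC(=O)N[C@H]1CCOC1=O` likewise gives only a limit, > 64000 nM. Compound 2 `O=C(CNc1ccc(Cl)cc1Cl)N[C@H]1CCOC1=O` also gives only a limit, > 64000 nM. Among the measured compounds shown here, compound 3 thus stands at the limit of > 64000 nM in this assay, at which 3 of the 3 values shown sit, and the one single-change step, a step that the two limits leave unreadable from compound 1 to compound 2, is unreadable. Compound 4 `O=C(CNc1ccc(Cl)cc1)N[C@H]1CCOC1=O` differs from compound 3 by chloro in place of fluoro on an aromatic carbon. Neither the chloro-bearing compounds 1 and 2 nor the fluoro-bearing compound 3 gives a number, so no direction can be read and no step beyond the scatter is expected. The estimated step is a step that the limit leaves unreadable from compound 3 to compound 4. Compound 4 is expected at 100000 nM, between 64000 nM and 300000 nM, most likely reported again only as a limit.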

Compound 4, half-maximal inhibitory concentration: > 64000 nM
Compound 4: a limit, no number (the forecaster's own chance of this, stated with the estimate: 85%); the middle value lies beyond the limit too.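

Among the compounds shown here, compound 4, like compounds 1, 2 and 3, gives only a limit in this assay, so no step among them can be read. The compounds shown leave open how chloro and fluoro actually compare.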